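Swapping the Methoxy-Bearing Arm for a Methyl-Bearing One

A few compounds are considered here, and "the series" means these few. Any claim that something is new, unique, unknown or untested is made for them only; others in the source may bear on it.

Measured so far:
compound 1 `O=C(NC1CCN(Cc2cccc(Cl)c2)CC1)c1cccc2ccccc12` — 116 nM
compound 2 `COc1cccc(CN2CCC(NC(=O)c3cccc4ccccc34)CC2)c1` — 168 nM

In an assay on isolated protein for displacement of a labelled ligand from D(4) dopamine receptor (Homo sapiens) (on this read-out higher numbers stand for weaker inhibition and lower numbers for stronger inhibition), compound 1 gives 116 nM and compound 2 gives 168 nM. Going by the values given here, the only measured step, a 1.4-fold higher number from compound 1 to compound 2 (0.16 log units; within the scatter), leaves the two numbers within the scatter of each other, so compound 2 is not separated from compound 1. Compound 3 `Cc1ccccc1CN1CCC(NC(=O)c2cccc3ccccc23)CC1` changes the same arm again: 2-methylphenyl in place of 3-methoxyphenyl on a saturated chain carbon bound to an amine nitrogen in a ring. That earlier step bears on this one and was small, so no step beyond the scatter is expected here. Compound 3 is therefore estimated at 150 nM, between 60 nM and 400 nM, an expected 1.1-fold lower number from compound 2 to compound 3 (0.05 log units; within the scatter).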

Compound 3, inhibition constant: 155 nM
For compound 3 the middle estimate is 1.0-fold (0.01 log units) below the measured one; measured number inside the range.
By their numbers in this assay, from the lowest: compounds 1, 3 and 2 (each within the scatter of the next).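

Putting 2-methylphenyl on the saturated chain carbon bound to an amine nitrogen in a ring gives a 1.1-fold lower number from compound 2 to compound 3 (0.03 log units; within the scatter) and, set against the 3-chlorophenyl arm, a 1.3-fold higher number from compound 1 to compound 3 (0.13 log units; within the scatter) in this assay. The 3-chlorophenyl, 3-methoxyphenyl and 2-methylphenyl arms therefore read alike here, even though the 2-methylphenyl arm has no hydrogen-bond acceptor where the 3-methoxyphenyl arm has one. No supporting measurement speaks to what lies behind this sameness. Still open, as far as these compounds go, is whether an arm of another kind stays this close: an amine or a carboxylic acid on the aromatic ring, or a longer chain carrying that ring.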